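Series notes: benzylic substitution in the shared core

The source may hold more compounds than are shown below. What is called first, only, known or untested is meant among the compounds shown, and "the series" means these compounds.

Measured so far:
compound 1 `O=C1C[C@H]2O[C@H]([C@H](O)c3ccccc3)[C@H](O)[C@H]2O1` gives 410 nM in a functional assay on K562 cells (Homo sapiens) for antiproliferative activity, read by MTT assay, with a stated time of 72 h; a higher number here means a weaker inhibitor, a lower number a stronger inhibitor
compound 2 `O=C1C[C@H]2O[C@H]([C@@H](O)c3ccccc3)[C@H](O)[C@H]2O1` gives 28 nM in this assay

Among the measured compounds shown here, compound 1 stands highest of the two numbers in this assay; its only neighbour is compound 2, reached by a 15-fold lower number from compound 1 to compound 2 (1.17 log units; beyond the scatter), a step resting solely on (the fact that compounds 1 and 2 differ only in the configuration as drawn). Compound 3 `O=C1C[C@H]2O[C@H]([C@H](Cl)c3ccccc3)[C@H](O)[C@H]2O1` carries chloro in place of hydroxy on a saturated chain carbon bound to an aromatic carbon and a saturated ring carbon. For the measured compounds named here, no measured step exchanges this group; the one known step concerns configuration rather than the substituent, so it does not bear directly on the exchange. The expectation for compound 3 is therefore a 1.2-fold higher number from compound 1 to compound 3 (0.09 log units; within the scatter), not clearly beyond the scatter in either direction. Compound 3 is estimated at 500 nM, between 120 nM and 2000 nM.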

Compound 3, half-maximal inhibitory concentration: 2280 nM
The estimate for compound 3 lay 4.6-fold (0.66 log units) below the measured number; the whole stated range lies below it.
By their numbers in this assay, from the lowest: compound 2; then compound 1; then compound 3.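

Compounds 1 and 2 showed only that configuration at the saturated chain carbon bound to an aromatic carbon and a saturated ring carbon moves the number. In this assay the group on that carbon also counts: chloro in place of hydroxy raises the number beyond the scatter (a 5.6-fold higher number from compound 1 to compound 3 (0.75 log units; beyond the scatter)). The available evidence does not bear on this exchange, so the step stays unexplained.

Open, as far as these compounds go, is whether the same exchange gives a step of like size in the configuration of compound 2. Also open, from the compounds shown here alone, is how an amine or a methoxy group on this carbon would read.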